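Bicyclic replacements for the tolyl group in the series

This account rests on a few compounds, and the source may have more. Where it says the series, first, only, none or still open, it means among the compounds named here.

Compound 1 `COc1cc(-c2ccnc3cc(-c4ccc(C)cc4)nn23)cc(OC)c1OC` gives the lowest number of the three measured compounds in a functional assay on MCF7 cells (Homo sapiens) for inhibition, read by CCK-8 assay, with a stated time of 48 h (a higher number here means a weaker inhibitor, a lower number a stronger inhibitor), at 47 nM. Compound 2 `COc1cc(-c2ccnc3cc(-c4cccc(C)c4)nn23)cc(OC)c1OC` gives 1080 nM, and compound 3 `COc1cc(-c2ccnc3cc(-c4ccc5ccn(C)c5c4)nn23)cc(OC)c1OC` gives 74 nM. The step of a 23-fold higher number from compound 1 to compound 2 (1.36 log units; beyond the scatter) is large, whereas a 1.6-fold higher number from compound 1 to compound 3 (0.20 log units; within the scatter) lies within the scatter, and a 15-fold lower number from compound 2 to compound 3 (1.16 log units; beyond the scatter) recovers most of what compound 2 loses.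

Compound 4 `COc1cc(-c2ccnc3cc(-c4ccc5cnn(C)c5c4)nn23)cc(OC)c1OC` differs from compound 1 by 1-methyl-1H-indazol-6-yl in place of 4-methylphenyl on an aromatic carbon. The step that bears most on it is a 1.6-fold higher number from compound 1 to compound 3 (0.20 log units; within the scatter). The 1-methyl-1H-indol-6-yl of compound 3 and the 1-methyl-1H-indazol-6-yl of compound 4 are both fused two-ring groups entering at the same place on the shared core. The large step of a 23-fold higher number from compound 1 to compound 2 (1.36 log units; beyond the scatter) shows how much can be lost in this assay, but compound 4 does not follow the route of compound 2. Only a small step is expected, a 1.6-fold higher number from compound 1 to compound 4 (0.20 log units; within the scatter), so compound 4 is estimated at 75 nM in this assay, with a range from 30 nM to 200 nM.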

Compound 4, half-maximal inhibitory concentration: 279 nM
For compound 4 the middle estimate is 3.7-fold (0.57 log units) below the measured one; measured number above the stated range.
By their numbers in this assay, from the lowest: compounds 1 and 3 (each within the scatter of the next); then compound 4; then compound 2.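

In this assay, fused two-ring groups at this position are not interchangeable: a 3.8-fold higher number from compound 3 to compound 4 (0.58 log units; beyond the scatter), a change confined to the five-membered ring of the entering group. The match between compound 1 and compound 3 therefore does not extend to every fused group, since a 5.9-fold higher number from compound 1 to compound 4 (0.77 log units; beyond the scatter). The 1-methyl-1H-indazol-6-yl group still stands on the favourable side of the 3-methylphenyl group, with a 3.9-fold lower number from compound 2 to compound 4 (0.59 log units; beyond the scatter), so compound 4 occupies a middle place among the four compounds rather than matching either extreme.

On these data alone, how a carboxylic acid or a dimethylamino group would fare in place of the methyl of the 4-methylphenyl group remains open. Nothing available explains the gap between the two fused groups.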